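Compound 1 and a sulfur drawn without configuration

The compounds below may be only part of what the source reports. "The series", "measured", "known", "first", "only" and "open" are said of these compounds alone.

In a functional assay on SNU-475 cells (Homo sapiens) for inhibition, read by sulforhodamine B assay, with a stated time of 72 h (on this read-out higher numbers stand for weaker inhibition and lower numbers for stronger inhibition), compound 1 (`COC1=CC(=O)C(C)=C([S@@+]([O-])c2ccc(C)cc2)C1=O`) gives 10500 nM and compound 2 (`CCOC1=CC(=O)C(C)=C([S@@+]([O-])c2ccc(C)cc2)C1=O`) gives 5500 nM on nearly the same level, while compound 3 (`Cc1ccc([S@+]([O-])C2=CC(=O)C=CC2=O)cc1`) gives a far lower 300 nM on the same read-out. Compound 4 (`COC1=CC(=O)C(C)=C([S+]([O-])c2ccc(C)cc2)C1=O`) has not been measured, and it differs from compound 1 only in how it is drawn (the two compounds have the same atoms and bonds; at least one stereo element is drawn with a configuration in one of them and without one in the other: 1 of 1 stereo elements differ; a stereocentre at a sulfur is drawn S in compound 1 and without a configuration in compound 4). For the measured compounds named here, the only measured step (a 1.9-fold lower number from compound 1 to compound 2 (0.28 log units; within the scatter)) concerns methyl in place of hydrogen on a saturated chain carbon, so no measured step tests a change at the sulfur. For compound 4 the expected step (a 1.1-fold lower number from compound 1 to compound 4 (0.02 log units; within the scatter)) is none beyond the scatter, in either direction. In this assay compound 4 is expected at 10000 nM (estimated range 5000 nM to 20000 nM).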

Compound 4, half-maximal inhibitory concentration: 6100 nM
Beside the measured number, compound 4's estimate is 1.6-fold (0.21 log units) above it; the measured number falls inside the stated range.
By their numbers in this assay, from the lowest: compound 3; then compounds 2, 4 and 1 (each within the scatter of the next).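

For the compounds shown here, this is the first measured comparison at the sulfur: in this assay there is a 1.7-fold lower number from compound 1 to compound 4 (0.24 log units; within the scatter). Leaving the sulfur's configuration undrawn therefore goes with a difference no larger than the usual scatter of repeats. The two compounds differ in only one respect: the fact that one of compounds 1 and 4 is drawn with a defined configuration and the other without, at the place where they differ

From the compounds shown here alone, the undrawn sulfur of compound 4 does not say which configuration or mixture its number describes, so whether configuration at this sulfur matters remains open. Also open, going by these compounds, is what a sulfone in place of the sulfoxide would give.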